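Dropping One Chloro From the Core of Compound 2

The compounds below may be only part of what the source reports. "The series", "measured", "known", "first", "only" and "open" are said of these compounds alone.

Compound 1 `ClCc1ccc(Cn2cnc3c(Cl)ncnc32)cc1`: 2340 nM
Compound 2 `ClCc1ccccc1Cn1cnc2c(Cl)nc(Cl)nc21`: 1470 nM

Both compounds were tested in a functional assay on SF-539 cells (Homo sapiens) for cytotoxicity, read by sulforhodamine B assay, with a stated time of 48 h; a higher number here means a weaker inhibitor of growth, a lower number a stronger inhibitor of growth. Compound 1 gives 2340 nM there, and compound 2 gives 1470 nM. Compound 2 thus stands at the low end of the two numbers shown, but compound 1 sits within the scatter of it, so the two are not truly distinguished by this assay.

Compound 3 `ClCc1ccccc1Cn1cnc2c(Cl)ncnc21` differs from compound 2 in one place: hydrogen in place of chloro on an aromatic carbon. Going by the values given here, no measured pair differs in exactly this way, so the size of this step has not been observed directly. What the data do show is that compound 1, which likewise carries a single chloro on its core, gives 2340 nM, close to what compound 2 gives. On that basis no step beyond the scatter is expected in this assay; the expected step from compound 2 to compound 3 is a 1.5-fold higher number from compound 2 to compound 3 (0.18 log units; within the scatter), a modest drift toward a weaker inhibitor of growth at most. Compound 3 is therefore estimated at 2200 nM, in a range from 900 nM to 5500 nM.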

Compound 3, concentration for 50% growth inhibition: 10700 nM
For compound 3 the middle estimate is 4.9-fold (0.69 log units) below the measured one; measured number above the stated range.
By their numbers in this assay, from the lowest: compounds 2 and 1 (each within the scatter of the next); then compound 3.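

In this assay, putting hydrogen in place of chloro on the aromatic carbon between two ring nitrogen atoms gives a 7.3-fold higher number from compound 2 to compound 3 (0.86 log units; beyond the scatter), a clear move toward a weaker inhibitor of growth. Compound 2 and compound 3 are the first pair shown to differ in this one place alone, so the effect of this chloro can now be read directly rather than inferred. The other chloro, meta to this position, and the chloromethyl-bearing benzyl part stay the same in both compounds, which ties the step to this single carbon, although no measurement shown here explains how the change acts on the cells.

With only chloro and hydrogen shown at this carbon, it remains open whether the number depends on chloro in particular or whether another group, such as an amine or a methoxy group, would give a similar result. Going by these compounds alone, it is also open whether the same step would appear with a different substitution pattern on the benzyl ring, such as the one in compound 1, or with the chloromethyl group replaced by a plain methyl group.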